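This account rests on a few compounds, and the source may have more. Where it says the series, first, only, none or still open, it means among the compounds named here.

Measured compounds:
- compound 1 `COc1ccc(-n2cc3nc(-c4cccnc4C)n(C[C@H]4CCCN(C[C@H]5CCCO5)C4)c(=O)c3n2)cc1`: 52 nM
- compound 2 `COc1cccc(-n2cc3nc(-c4cccnc4C)n(C[C@H]4CCCN(CC5CCCCC5)C4)c(=O)c3n2)c1`: 200 nM
- compound 3 `Cc1ccccc1-c1nc2cn(-c3cccc(C#N)c3)nc2c(=O)n1CC1CCCN(C(C)C)C1`: 32 nM

In an assay on HEK293 cells for displacement of a labelled ligand from growth hormone secretagogue receptor type 1 (Homo sapiens), with a stated time of 60 min (on this read-out lower numbers stand for stronger inhibition and higher numbers for weaker inhibition), compound 1 gives 52 nM, the second highest of the three numbers. Compound 3 gives 32 nM, which lies within the scatter of compound 1, so the two cannot be told apart. Compound 2 gives 200 nM, a number beyond the scatter above compound 1.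

Compound 4 `Cc1ncccc1-c1nc2cn(-c3cccc(OC(C)C)c3)nc2c(=O)n1C[C@H]1CCCN(C[C@H]2CCCO2)C1` differs from compound 1 in one place: 3-isopropoxyphenyl in place of 4-methoxyphenyl on an aromatic nitrogen. Among the compounds with values here, no pair among the measured compounds isolates this change, and compounds 2 and 3 differ from compound 1 in more than one place, so the three measured values cannot fix the size of the step. On that basis only a small step is expected, a 1.3-fold higher number from compound 1 to compound 4 (0.13 log units; within the scatter), in no direction that goes clearly beyond the scatter. Compound 4 is therefore estimated to give 70 nM in this assay, with a range of 20 nM to 240 nM.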

Compound 4, half-maximal inhibitory concentration: 11 nM
Beside the measured number, compound 4's estimate is 6.4-fold (0.80 log units) above it; measured number outside the range, below it.
By their numbers in this assay, from the lowest: compound 4; then compounds 3 and 1 (each within the scatter of the next); then compound 2.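

In this assay, the aryl group on the aromatic nitrogen proves able to move the number on its own: 3-isopropoxyphenyl in place of 4-methoxyphenyl gives a 4.7-fold lower number from compound 1 to compound 4 (0.67 log units; beyond the scatter). The earlier compounds shown here differed from one another in more than one place, so they could not show what this position contributes; this single change now shows a step beyond the scatter. Nothing among the data given accounts for the size or direction of this step.

The change alters both the place of the ether on the phenyl ring and the ether group itself, and the compounds shown do not separate these two contributions. They also leave open how an ethoxy group or a longer chain such as butoxy on the phenyl ring would read in this assay.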